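The source may report more compounds than this note shows. Statements on the series, on what has been measured and on what is new or still open speak of the compounds shown alone.

Measured compounds:
compound 1, `CCN(c1ccc(C#N)c(Cl)c1)c1cc(-n2ccnc2)ccc1C`: > 30000 nM
compound 2, `N#Cc1ccc(N2CCc3cc(-c4cncnc4)ccc3C2)cc1C(F)(F)F`: "not determined" (no result reported)
compound 3, `CCN(c1cccc(-c2cncnc2)c1)c1ccc(C#N)c(Cl)c1`: > 30000 nM

The study looks at a functional assay on CWR22R cells (Homo sapiens) for antiproliferative activity, read by CCK-8 assay, with a stated time of 6 days; on this read-out higher numbers stand for weaker inhibition and lower numbers for stronger inhibition. Compound 1 reaches only the limit of the assay, > 30000 nM, and not a number. Compound 3 likewise stops at the limit, > 30000 nM. Compound 2 has no result at all in this assay, so it is reported as "not determined" (no result reported). The two other values in this assay are both limits rather than numbers, and this is summed up in the limit of > 30000 nM in this assay, at which 2 of the 3 values shown sit. Compound 2 therefore stands nowhere on a numerical scale: nothing within the measured set places it either among the inactive compounds or apart from them.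

The unmeasured compound 4, `N#Cc1ccc(N2CCc3cc(-c4ccncc4)ccc3C2)cc1C(F)(F)F`, differs from compound 2 in one place: pyridin-4-yl in place of pyrimidin-5-yl on an aromatic carbon. Going by the values given here, no step between measured compounds is available for this change, so its size in this assay is unknown, and the only guide is that two of the three measured compounds fail to reach a number. Compound 4 is expected to sit with some chance at the limit as well, and where it does give a number it is estimated at 10000 nM, in a range from 1000 nM to 30000 nM.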

Compound 4, half-maximal inhibitory concentration: 6940 nM
For compound 4 the middle estimate is 1.4-fold (0.16 log units) above the measured one, and the stated range covers the measured number.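

In this assay compound 4 stands at 6940 nM and yields no new step: compound 2, the one compound shown that differs from it in a single place, is reported as "not determined" (no result reported) and offers no number to compare. The compounds shown leave open what replacing pyrimidin-5-yl with pyridin-4-yl does to antiproliferative activity on its own.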